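Trading a Nitrile Tail for a Plain Hexyl Chain

A few compounds are considered here, and "the series" means these few. Any claim that something is new, unique, unknown or untested is made for them only; others in the source may bear on it.

Compound 1 `C=CCc1cc(C(C)=O)c(O)cc1OCCCC#N` was tested in an assay on isolated protein for binding affinity to leukotriene B4 receptor 1 (Homo sapiens), tested at 1 uM (on this read-out higher numbers stand for more inhibition at the one concentration tested (going by the name of the read-out) and lower numbers for less inhibition), where compound 1 gives 6%. For the measured compounds named here, that is the lower of the two numbers measured so far: compound 2 `CCc1cc(C(C)=O)c(O)cc1OCCCCCC(C)(C)C#N` gives 53% in this assay, a gap well beyond the usual scatter. Compound 3 `C=CCc1cc(C(C)=O)c(O)cc1OCCCCCC` has not yet been measured. It differs from compound 1 in one place: propyl in place of cyano on a saturated chain carbon, three bonds along the chain from an oxygen on an aromatic ring. Going by the values given here, no step between measured compounds differing in a single place is available, so the step from compound 1 to compound 3 is expected to be a modest rise, a number 19 percentage points higher from compound 1 to compound 3 (beyond the scatter). Compound 3 is therefore estimated at 25%, within 5% to 55%.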

Compound 3, a percentage reported as inhibition, at one concentration (the size of the read-out at that concentration, not a potency): 9%
Compound 3: the middle estimate sits 16 percentage points above what was measured; the measured number falls inside the stated range.
By their numbers in this assay, from the lowest: compounds 1 and 3 (each within the scatter of the next); then compound 2.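

In this assay, putting propyl in place of cyano at this place on the chain gives a number 3 percentage points higher from compound 1 to compound 3 (within the scatter) and so leaves the reading unchanged. On the core of compound 1, the 3-cyanopropyl and hexyl chains therefore read alike, which shows that the nitrile can be exchanged here for plain carbon without a measurable change. Nothing available explains why these two chains read alike.

Still open, from the compounds shown here alone, is whether an amine or a carboxylic acid at the chain end, or a longer chain, would shift the reading on this core. Going by these compounds, whether cyano and propyl also read alike on other cores remains open too.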